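Notes on the series: anilino in place of methylsulfanyl

The compounds below may be only part of what the source reports. "The series", "measured", "known", "first", "only" and "open" are said of these compounds alone.

Compound 1 `CCCCN1CCN(C(=S)SC(=S)N(C)C)CC1` gives 4100000 nM in an ADME assay on HeLa cells (Homo sapiens) for cytotoxicity, read by MTT assay, with a stated time of 24 h; a lower number here means a stronger inhibitor, a higher number a weaker inhibitor. Compound 2 `CCOC(=O)N1CCN(C(=S)SC(=S)N(C)C)CC1` gives 530000 nM in this assay, and exchanging butyl for ethoxycarbonyl on the ring amine nitrogen runs to a 7.7-fold lower number from compound 1 to compound 2 (0.89 log units; beyond the scatter). Compound 3 `CSC(=S)N1CCN(C(=S)SC(=S)N(C)C)CC1` is reported in this assay as > 5000000 nM, which is a limit of the assay (the limit of > 5000000 nM in this assay, at which 1 of the 3 values shown sits). The steps reaching compound 3 read an at least 1.2-fold higher number from compound 1 to compound 3 (0.08 log units; that floor lies within the scatter) and an at least 9.4-fold higher number from compound 2 to compound 3 (0.97 log units; beyond the scatter), so compound 3 sits at the weak end of the three numbers shown, the gap to compound 1 being within the scatter.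

Compound 4 `CN(C)C(=S)SC(=S)N1CCN(C(=S)Nc2ccccc2)CC1` is not yet measured in this assay. The change from compound 3 is anilino in place of methylsulfanyl on a thiocarbonyl carbon. Going by the values given here, no measured step touches the thiocarbonyl carbon; all three known steps swap the substituent on the ring amine nitrogen, and the two beyond the scatter, a 7.7-fold lower number from compound 1 to compound 2 (0.89 log units; beyond the scatter) and an at least 9.4-fold higher number from compound 2 to compound 3 (0.97 log units; beyond the scatter), move the number by a modest amount in opposite directions. The size of the present step is therefore open, with a shift away from the limit of compound 3 toward the region of compound 2 plausible but not supported by a like-for-like comparison. Compound 4 is expected at about 1500000 nM, within 300000 nM to 6000000 nM, an estimated step of an at least 3.3-fold lower number from compound 3 to compound 4 (0.52 log units; beyond the scatter).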

Compound 4, half-maximal inhibitory concentration: > 5000000 nM
Compound 4 gave a limit, no number; the forecaster's own chance of this, stated with the estimate: 25%; middle value at least 3.3-fold (0.52 log units) from the limit.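

In this assay compound 4 is reported as > 5000000 nM, which is a limit and not a number. Compound 3 also stands at a limit, so no step between compound 3 and compound 4 can be read: the limit of > 5000000 nM in this assay, at which 2 of the 4 values shown sit.

The compounds shown leave open how anilino in place of methylsulfanyl on a thiocarbonyl carbon moves the number in this assay.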